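Removing the ring hydroxy from compound 3

The source may hold more compounds than are shown below. What is called first, only, known or untested is meant among the compounds shown, and "the series" means these compounds.

Measured so far in a functional assay on MCF7 cells (Homo sapiens) for inhibition, read by resazurin assay, with a stated time of 72 h; on this read-out lower numbers stand for stronger inhibition and higher numbers for weaker inhibition:
compound 1 `CCSc1ccc(C2C(O)C(=O)N2c2cc(OC)c(OC)c(OC)c2)cc1` gives 6 nM
compound 2 `COc1ccc(C2C(O)C(=O)N2c2cc(OC)c(OC)c(OC)c2)cc1O` gives 3 nM
compound 3 `CCOc1ccc(C2C(O)C(=O)N2c2cc(OC)c(OC)c(OC)c2)cc1` gives 7 nM

Compound 3 stands close to one neighbour and modestly apart from the other (a 1.2-fold higher number from compound 1 to compound 3 (0.07 log units; within the scatter) and a 2.3-fold higher number from compound 2 to compound 3 (0.37 log units; beyond the scatter)). Compound 4 `CCOc1ccc(C2CC(=O)N2c2cc(OC)c(OC)c(OC)c2)cc1` carries hydrogen in place of hydroxy on a saturated ring carbon. Among the measured compounds shown here, no measured step touches that hydroxy. All three measured compounds carry it, and their steps changed other groups only, so the data hold no direct test. Compound 3 at 7 nM keeps the hydroxy, and losing it is expected to give a larger step than those, towards a higher number in this assay as a cautious guess. The expected step is a 7.1-fold higher number from compound 3 to compound 4 (0.85 log units; beyond the scatter) by estimate. For compound 4 the estimated value is 50 nM (range 12 nM to 300 nM).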

Compound 4, half-maximal inhibitory concentration: 64 nM
Compound 4: the middle estimate sits 1.3-fold (0.11 log units) below what was measured, within the range that was stated.
By their numbers in this assay, from the lowest: compounds 2, 1 and 3 (each within the scatter of the next, the first and the last beyond it); then compound 4.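

Hydroxy on this saturated ring carbon matters in this assay: hydrogen in its place gives a 9.1-fold higher number from compound 3 to compound 4 (0.96 log units; beyond the scatter). Among the compounds shown here, this is the first change at this position, and the step is larger than any among the earlier compounds, whose changes left the hydroxy in place. Nothing available explains why the loss of this group has such an effect.

Going by these compounds, it remains open whether an amine or fluorine on this ring carbon would keep the number near that of compound 3 or move it towards that of compound 4. Also open, on these data alone, is whether removing the hydroxy would give a similar step with the 3-hydroxy-4-methoxyphenyl group of compound 2.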